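Ethoxycarbonyl to pyridin-3-yl on the aromatic nitrogen

The source may hold more compounds than are shown below. What is called first, only, known or untested is meant among the compounds shown, and "the series" means these compounds.

Of the compounds shown here, two have been read so far. In a functional assay on the whole organism with Mus musculus as the target (a lower number here means that less compound is needed, a higher number that more compound is needed for the effect), compound 1 (`CCCSCC1(C)Cc2c(C)c(N)c(C)c(C)c2O1`) gives 24.6 mg/kg as a measured number. In this assay compound 2 (`CCOC(=O)Nc1c(C)c(C)c2c(c1C)CC(C)(C)O2`) stands at > 100 mg/kg and this is a limit of the assay and not a number.

Compound 3 (`Cc1c(C)c2c(c(C)c1Nc1cccnc1)CC(C)(C)O2`) differs from compound 2 by pyridin-3-yl in place of ethoxycarbonyl on a nitrogen on an aromatic ring. Within the data shown here, no measured pair isolates this change, so the size of the step is a matter of expectation alone. Among the measured compounds shown here, the one number available is compound 1 at 24.6 mg/kg and its nitrogen carries no ethoxycarbonyl either, which is slender support for a move towards a lower dose. The expected step in this assay is an at least 3.3-fold lower number from compound 2 to compound 3 (0.52 log units; beyond the scatter) in that direction, and its size stays uncertain while the starting point is only a limit. A second limit remains possible. For compound 3 the estimated value is 30 mg/kg with an expected range from 8 mg/kg to 100 mg/kg in this assay once measured.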

Compound 3, dose for 50% inhibition: > 50 mg/kg
Compound 3: no number, only a limit (the forecaster's own chance of this, stated with the estimate: 30%); middle value at least 1.6-fold (0.22 log units) away from the limit.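

In this assay compound 2 stands at > 100 mg/kg, a limit of the assay and not a number. Among these compounds, compound 3 stands at > 50 mg/kg, again a limit, and no step between compound 2 and compound 3 can be read. The compounds shown leave open the size and direction of any effect of exchanging ethoxycarbonyl for pyridin-3-yl on this nitrogen.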